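Boronic acid arginine amides: sulfamoyl for trifluoromethyl

This account rests on a few compounds, and the source may have more. Where it says the series, first, only, none or still open, it means among the compounds named here.

Measured so far:
- compound 1 `CC1(C)C2CC1[C@]1(C)OB([C@H](CCCN=C(N)N)NC(=O)c3ccc(-c4ccccc4)cc3)O[C@@H]1C2`: 33 nM
- compound 2 `CC(C)(C)OC(=O)Nc1cccc(-c2ccc(C(=O)N[C@@H](CCCN=C(N)N)B3O[C@@H]4CC5CC(C5(C)C)[C@]4(C)O3)s2)c1`: 13 nM
- compound 3 `Cc1cc(-c2ccccc2C(F)(F)F)ccc1C(=O)N[C@@H](CCCN=C(N)N)B1O[C@@H]2CC3CC(C3(C)C)[C@]2(C)O1`: 3.1 nM

Three amides on a shared boronate core have been run in an assay on isolated protein for inhibition of serine protease 1 (Homo sapiens); on this read-out higher numbers stand for weaker inhibition and lower numbers for stronger inhibition. Of the three values, compound 3 gives the lowest number and is the most potent of the set: compound 2 lies a step above it that is beyond the scatter, and compound 1 a larger step above that again. Among the compounds with values here, no pair of these differs in a single place, so no single-point step is available as a guide.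

Compound 4 `CCN(CC)S(=O)(=O)c1ccccc1-c1ccc(C(=O)N[C@@H](CCCN=C(N)N)B2O[C@@H]3CC4CC(C4(C)C)[C@]3(C)O2)c(C)c1` is the next compound and differs from compound 3 in one place: diethylsulfamoyl in place of trifluoromethyl on an aromatic carbon. Within the data shown here, the group that enters is larger and carries acceptors, at a site ortho to a large group, and nothing among the measured compounds reports how such a group behaves on this read-out. A modest move toward a higher number is expected from compound 3 to compound 4, with a wide range, estimated as a 1.9-fold higher number from compound 3 to compound 4 (0.29 log units; within the scatter). In this assay compound 4 is expected to give about 6 nM, between 1.5 nM and 25 nM.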

Compound 4, inhibition constant: 0.62 nM
The estimate for compound 4 lay 9.7-fold (0.99 log units) above the measured number; measured number outside the range, below it.
By their numbers in this assay, from the lowest: compound 4; then compound 3; then compound 2; then compound 1.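

In this assay, the aromatic carbon ortho to a large group accepts far more than trifluoromethyl: diethylsulfamoyl, with 8 heavy atoms against 4 and 2 hydrogen-bond acceptors against 0, gives a 5.0-fold lower number from compound 3 to compound 4 (0.70 log units; beyond the scatter) and so lies beyond the scatter. This place is therefore not restricted to a group the size of trifluoromethyl, and the larger group gives the stronger inhibition of this pair. Nothing available bears on what lies behind this step.

Heavy-atom count and acceptor count change together in this one step, so their contributions cannot be separated. A methylsulfonyl group would show how much of the step survives without the diethylamino part, and an unsubstituted sulfamoyl group or a piperidine-1-sulfonyl group would show how far the ethyl chains matter.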